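Amino in Place of Hydroxy on the Benzyl Amide

The source may hold more compounds than are shown below. What is called first, only, known or untested is meant among the compounds shown, and "the series" means these compounds.

Of the compounds shown here, three sharing one core have been measured in a functional assay on cells for antagonist activity at C-C chemokine receptor type 1 (Homo sapiens), read by FLIPR and calcium flux; on this read-out lower numbers stand for stronger inhibition and higher numbers for weaker inhibition. Compound 1 `Cc1c(C(=O)NCc2cccc(C(F)(F)F)c2)cnn1-c1ccc(Cl)cc1` gives 600 nM in this assay. Compound 2 `O=C(NCc1cccc(C(F)(F)F)c1)c1cnn(-c2ccc(Cl)cc2)c1C(F)(F)F` gives > 3000 nM in this assay, which is a limit of the assay and not a number. Compound 3 `Cc1c(C(=O)NCc2cccc(O)c2)cnn1-c1ccc(Cl)cc1` gives > 3000 nM in this assay, again a limit rather than a number. Compound 3 therefore stands at the limit of > 3000 nM in this assay, at which 2 of the 3 values shown sit, and only a limit is known for it.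

Two steps are known: an at least 5.0-fold higher number from compound 1 to compound 2 (0.69 log units; beyond the scatter) and an at least 5.0-fold higher number from compound 1 to compound 3 (0.69 log units; beyond the scatter). Both run toward weaker inhibition, and the second already turned the trifluoromethyl of compound 1 into the hydroxy of compound 3.

Compound 4 `Cc1c(C(=O)NCc2cccc(N)c2)cnn1-c1ccc(Cl)cc1` differs from compound 3 by amino in place of hydroxy on an aromatic carbon. One heavy atom is exchanged for one heavy atom, with donor and acceptor count unchanged. Among the compounds with values here, since compound 3 sits at a limit, its step from the trifluoromethyl of compound 1 being the only guide, no shift beyond the scatter is expected. The expected change is a step that the limit leaves unreadable from compound 3 to compound 4. Compound 4 is thus estimated at 3500 nM, between 900 nM and 12000 nM.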

Compound 4, half-maximal inhibitory concentration: > 3000 nM
Compound 4 gave a limit, no number; the forecaster's own chance of this, stated with the estimate: 55%; the middle value lies beyond the limit too.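

In this assay compound 4 gives > 3000 nM, which is a limit of the assay and not a number. Amino in place of the trifluoromethyl gives an at least 5.0-fold higher number from compound 1 to compound 4 (0.69 log units; beyond the scatter), so amino joins the hydroxy of compound 3 as a second group on this aromatic carbon that falls short of compound 1. The step between compound 3 and compound 4 cannot be read, so hydroxy and amino cannot be ranked against each other, and both stand at the same point: the limit of > 3000 nM in this assay, at which 3 of the 4 values shown sit.

From the compounds shown here alone, how much weaker compound 3 and compound 4 really are remains unknown. Also open, going by these compounds, is whether a chloro, methoxy or nitrile group at this place would match or improve on the trifluoromethyl of compound 1, which gives 600 nM.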